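The source may hold more compounds than are shown below. What is called first, only, known or untested is meant among the compounds shown, and "the series" means these compounds.

Three related compounds have been measured so far in a functional assay on A549 cells (Homo sapiens) for antiproliferative activity, read by MTT assay, with a stated time of 48 h; on this read-out higher numbers stand for weaker inhibition and lower numbers for stronger inhibition. Compound 3 (`COc1cccc(-c2nn(-c3ccccc3)cc2C(Nc2nc3ccc(Cl)cc3s2)c2c(O)ccc3ccccc23)c1`) gives 49800 nM. Compound 2 (`O=[N+]([O-])c1cccc(-c2nn(-c3ccccc3)cc2C(Nc2nc3ccc(Cl)cc3s2)c2c(O)ccc3ccccc23)c1`) gives 42500 nM, which lies within the scatter of compound 3. Compound 1 (`COc1ccc2nc(NC(c3cn(-c4ccccc4)nc3-c3ccc([N+](=O)[O-])cc3)c3c(O)ccc4ccccc34)sc2c1`) gives 22500 nM, a lower number than compound 3 by more than the scatter. Compound 3 therefore sits level with compound 2, and compound 1 stands apart from both.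

Compound 4 (`O=[N+]([O-])c1ccc(-c2nn(-c3ccccc3)cc2C(Nc2nc3ccc(Cl)cc3s2)c2c(O)ccc3ccccc23)cc1`) differs from compound 3 in one place: 4-nitrophenyl in place of 3-methoxyphenyl on an aromatic carbon. For the measured compounds named here, only one measured step bears directly on this swap: a 1.2-fold higher number from compound 2 to compound 3 (0.07 log units; within the scatter), with methoxy in place of nitro on an aromatic carbon. That step runs in the opposite sense and stays within the scatter, although compound 2 carries its nitro at a different position from compound 4. Compound 1, at 22500 nM, carries the same 4-nitrophenyl as compound 4 but also differs from it elsewhere, so it offers only a loose hint towards a lower number. Going by the values given here, no measured step isolates the 4-nitrophenyl itself.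

The expected change is a 1.3-fold lower number from compound 3 to compound 4 (0.12 log units; within the scatter), a small move towards a lower number in this assay that probably stays within the scatter. For compound 4 the estimated value is 38000 nM, with an expected range of 20000 nM to 62000 nM.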

Compound 4, half-maximal inhibitory concentration: 57200 nM
For compound 4 the middle estimate is 1.5-fold (0.18 log units) below the measured one; measured number inside the range.
By their numbers in this assay, from the lowest: compounds 1, 2, 3 and 4 (each within the scatter of the next, the first and the last beyond it).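

In this assay, neither the step of a 1.1-fold higher number from compound 3 to compound 4 (0.06 log units; within the scatter) nor the step of a 1.3-fold higher number from compound 2 to compound 4 (0.13 log units; within the scatter) separates these groups on this aromatic carbon of the five-membered ring: with the chloro compounds, swapping 3-methoxyphenyl for 4-nitrophenyl or moving the nitro from the 3-nitrophenyl to the 4-nitrophenyl arrangement leaves the result within the usual scatter. For the compounds shown here, the only step beyond the scatter is a 2.5-fold higher number from compound 1 to compound 4 (0.41 log units; beyond the scatter), where 4-nitrophenyl stays in place and chloro replaces methoxy elsewhere on the molecule, so the number of compound 1 cannot be credited to 4-nitrophenyl alone. No supporting measurement is available to explain any of these steps.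

Going by these compounds, the chloro-for-methoxy change has been read only with 4-nitrophenyl present, so it remains open whether it would give a similar step with 3-nitrophenyl or 3-methoxyphenyl at the same position. Also open is whether a group of a different kind on this phenyl ring, such as an amine or a carboxylic acid, would move the number beyond the scatter, since the compounds shown carry only nitro or methoxy there.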